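The source may report more compounds than this note shows. Statements on the series, on what has been measured and on what is new or still open speak of the compounds shown alone.

Three compounds share one core: compound 1 `O=C(Nc1cccc(OCc2cn(-c3ccccc3)nn2)c1)Nc1ccc(Cl)c(C(F)(F)F)c1`, compound 2 `CCc1ccc(-n2cc(COc3cccc(NC(=O)Nc4ccc(Cl)c(C(F)(F)F)c4)c3)nn2)cc1` and compound 3 `O=C(Nc1cccc(OCc2cn(-c3ccccc3F)nn2)c1)Nc1ccc(Cl)c(C(F)(F)F)c1`. In a functional assay on HepG2 cells (Homo sapiens) for inhibition, read by MTT assay, with a stated time of 72 h (on this read-out lower numbers stand for stronger inhibition and higher numbers for weaker inhibition), compound 1 gives 1780 nM, compound 2 gives 1950 nM and compound 3 gives 1520 nM. Compound 3 sits within the scatter of both neighbours, as a 1.2-fold lower number from compound 1 to compound 3 (0.07 log units; within the scatter) and a 1.3-fold lower number from compound 2 to compound 3 (0.11 log units; within the scatter) show, and a 1.1-fold higher number from compound 1 to compound 2 (0.04 log units; within the scatter) is likewise within the scatter. Compound 4 `O=C(Nc1cccc(OCc2cn(-c3cccc(Br)c3)nn2)c1)Nc1ccc(Cl)c(C(F)(F)F)c1` is not yet measured; the change is 3-bromophenyl in place of 2-fluorophenyl on an aromatic nitrogen. Among the measured compounds shown here, the one earlier swap of the whole group on that nitrogen, a 1.3-fold lower number from compound 2 to compound 3 (0.11 log units; within the scatter), and the single-atom changes on that ring, a 1.1-fold higher number from compound 1 to compound 2 (0.04 log units; within the scatter) and a 1.2-fold lower number from compound 1 to compound 3 (0.07 log units; within the scatter), all stayed within the scatter, so nothing beyond the scatter is expected in this assay here. For compound 4 the expected step is a 1.1-fold higher number from compound 3 to compound 4 (0.02 log units; within the scatter). Compound 4 is estimated at 1600 nM, between 900 nM and 3000 nM.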

Compound 4, half-maximal inhibitory concentration: 1040 nM
Estimate against measurement, compound 4: 1.5-fold (0.19 log units) above, and the stated range covers the measured number.
By their numbers in this assay, from the lowest: compounds 4, 3, 1 and 2 (each within the scatter of the next).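

On the aromatic nitrogen, 3-bromophenyl keeps every step within the scatter in this assay: a 1.5-fold lower number from compound 3 to compound 4 (0.16 log units; within the scatter), a 1.7-fold lower number from compound 1 to compound 4 (0.23 log units; within the scatter) and a 1.9-fold lower number from compound 2 to compound 4 (0.27 log units; within the scatter). The last of these is the largest step yet seen at this position, so a bromo substituent, like ethyl and fluoro before it, gives no separation among the four compounds. No supporting data bear on these small steps.

Going by these compounds, whether an amine, a carboxylic acid or a longer chain on this phenyl ring would produce a step beyond the scatter remains open.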